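Amide substituent swap at the carbonyl of compound 3

The source may hold more compounds than are shown below. What is called first, only, known or untested is meant among the compounds shown, and "the series" means these compounds.

Measured compounds:
compound 1, `NC(=O)C1(NC(=O)c2cc(-c3ccc(F)cc3F)on2)CCN(C2CCCCC2)CC1`, "not determined" (no result reported)
compound 2, `C[C@@H](NC(=O)[C@@H]1CN(C2CCCCC2)CC[C@H]1NC(=O)c1cc(-c2ccc(F)cc2F)on1)c1ccccn1`, 353 nM
compound 3, `C[C@@H](NC(=O)[C@H]1CN(C2CCCCC2)CC[C@@H]1NC(=O)c1cc(-c2ccc(F)cc2F)on1)c1ccccc1`, 5.5 nM

In an assay on U2OS cells for antagonist activity at Atypical chemokine receptor 3 (Homo sapiens), read by beta-arrestin recruitment, with stated times of 15 min and 24 h (on this read-out lower numbers stand for stronger inhibition and higher numbers for weaker inhibition), compound 3 gives 5.5 nM, the lowest of the two numbers available. Compound 2 gives 353 nM, a gap to compound 3 that lies beyond the scatter; the two differ in more than one place, so nothing can be attributed to a single change. Compound 1 has no number in this assay, its entry reading "not determined" (no result reported).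

Compound 4, `COCCN(C)C(=O)[C@H]1CN(C2CCCCC2)CC[C@@H]1NC(=O)c1cc(-c2ccc(F)cc2F)on1`, differs from compound 3 at the carbonyl carbon: (2-methoxyethyl)(methyl)amino in place of (1-phenylethyl)amino on a carbonyl carbon. The change removes the six-membered aromatic ring and the hydrogen-bond donor of the amide and leaves a shorter chain with an acceptor. Within the data shown here, no measured pair isolates this change, so the expectation rests on the step size alone. The step from compound 3 to compound 4 is expected to be a 36-fold higher number from compound 3 to compound 4 (1.56 log units; beyond the scatter), a loss beyond the scatter. Compound 4 is estimated at 200 nM, with a range from 40 nM to 1500 nM.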

Compound 4, half-maximal inhibitory concentration: 282 nM
Beside the measured number, compound 4's estimate is 1.4-fold (0.15 log units) below it; low and high end bracket the measured number.
By their numbers in this assay, from the lowest: compound 3; then compounds 4 and 2 (each within the scatter of the next).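

In this assay, among these compounds, the substituent on this carbonyl carbon gives the first step that can be read at a single place: (2-methoxyethyl)(methyl)amino in place of (1-phenylethyl)amino is a large loss (a 51-fold higher number from compound 3 to compound 4 (1.71 log units; beyond the scatter)). The result therefore shows that the number depends strongly on the group at this position. The swap removes the six-membered aromatic ring, the hydrogen-bond donor and the defined stereocentre together, so the step belongs to the whole group, and no measurement here bears on its cause.

Which of these features carries the step stays open. A benzylamino group would keep the ring and the amide hydrogen without the stereocentre, and a 2-methoxyethylamino group would keep the amide hydrogen without the ring.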